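This account rests on a few compounds, and the source may have more. Where it says the series, first, only, none or still open, it means among the compounds named here.

Measured in a functional assay on CCRF-CEM cells (Homo sapiens), read by MTT assay, with a stated time of 72 h; a lower number here means a stronger inhibitor, a higher number a weaker inhibitor:
- Compound 1 `CSc1ncnc2c1c(-c1cccs1)cn2[C@@H]1O[C@H](CO)[C@@H](O)[C@H]1O`: > 20000 nM
- Compound 2 `Nc1nc(N)c2c(-c3ccco3)cn([C@@H]3O[C@H](CO)[C@@H](O)[C@H]3O)c2n1`: > 20000 nM
- Compound 3 `COc1nc(N)nc2c1c(-c1ccco1)cn2[C@@H]1O[C@H](CO)[C@@H](O)[C@H]1O`: > 20000 nM

Each of these three entries is a limit and not a number. Compound 3 therefore has no exact place on the scale. In this assay compound 3 gives > 20000 nM, which is a limit. It shares that position with both other compounds, as the summary shows: the limit of > 20000 nM in this assay, at which 3 of the 3 values shown sit.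

Compound 4 `COc1nc(N)nc2c1c(-c1ccccc1)cn2[C@@H]1O[C@H](CO)[C@@H](O)[C@H]1O` keeps the methoxy and amino groups of compound 3 and changes one substituent, with phenyl in place of furan-2-yl on an aromatic carbon. For the measured compounds named here, no measured step exchanges this group, so nothing shows directly what the swap does. Going by the values given here, the only measured step is a step that the two limits leave unreadable from compound 2 to compound 3, and it concerns another site and gives no size to carry over. With every measured compound at the limit, the data offer no sign of a stronger inhibitor, so no readable change is expected in this assay, in either direction.

The most likely outcome is that the assay again reports only a limit. The estimate corresponds to a step that the limit leaves unreadable from compound 3 to compound 4, an expected step with no meaningful size. For compound 4 the estimated value is 25000 nM, with an expected range of 8000 nM to 60000 nM.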

Compound 4, half-maximal inhibitory concentration: > 20000 nM
Compound 4: no number, only a limit; the forecaster's own chance of this, stated with the estimate: 85%; the middle value is on the limit's open side.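

In this assay compound 4 gives > 20000 nM, which is a limit and not a number. For the compounds shown here, with compound 3 also at a limit, no step from compound 3 to compound 4 can be read. All the compounds shown share one position: the limit of > 20000 nM in this assay, at which 4 of the 4 values shown sit.

The compounds shown leave open how strong any of them actually is, and which change, if any, would yield a readable value.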